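Adding a Pyridin-4-yl Ring to Compound 1

This account rests on a few compounds, and the source may have more. Where it says the series, first, only, none or still open, it means among the compounds named here.

Compound 1, `Nc1sccc1C(=O)c1ccc(Cl)cc1`: 40%
Compound 2, `CN(C)c1ccc(-c2cc(C(=O)c3ccccc3)c(N)s2)cc1`: 29%
Compound 3, `COc1ccc(-c2cc(C(=O)c3ccc(Cl)cc3)c(N)s2)cc1`: 29%

Of the compounds shown here, three share a core and have been tested in an assay on CHO cells for positive allosteric modulation of adenosine receptor A1 (Homo sapiens), read by ERK phosphorylation, tested at 10 uM; a lower number here means a stronger effect, a higher number a weaker effect of the compound at the concentration tested. Compound 1 gives 40%, the highest of the three numbers, which here means the weakest effect at the concentration tested. Compound 2 gives 29% and compound 3 gives 29%; each lies beyond the scatter below compound 1. Both compound 2 and compound 3 carry an aromatic ring on the core where compound 1 carries only hydrogen, though they differ from compound 1 in more than one place, so no single step can be read from them.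

Compound 4, `Nc1sc(-c2ccncc2)cc1C(=O)c1ccc(Cl)cc1`, has not yet been measured. It differs from compound 1 in one place: pyridin-4-yl in place of hydrogen on an aromatic carbon. Since compound 2 and compound 3, which both carry an aromatic ring at this position, show lower numbers than compound 1, a lower number is expected for compound 4 as well, with a step of a number 10 percentage points lower from compound 1 to compound 4 (within the scatter) beyond the scatter. In this assay compound 4 is estimated to give 30%, with a likely range from 18% to 45%.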

Compound 4, a percentage reported as activity, at one concentration (the size of the read-out at that concentration, not a potency): 17%
For compound 4 the middle estimate is 13 percentage points above the measured one, and the stated range ends above it.
By their numbers in this assay, from the lowest: compound 4; then compounds 2 and 3 (each within the scatter of the next); then compound 1.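

Pyridin-4-yl in place of hydrogen on the aromatic carbon next to the ring sulfur gives a number 23 percentage points lower from compound 1 to compound 4 (beyond the scatter) in this assay. Going by these compounds alone, only this one group changes, so this is the first effect at this position that can be read on its own: the added ring, which carries a nitrogen, gives a stronger effect at the concentration tested. Nothing measured here explains why the number falls.

As far as these compounds go, whether the ring nitrogen matters remains open, and a plain phenyl ring or a pyridin-3-yl ring at this position on the same core would help to separate its role from that of the ring as a whole. It is also unclear whether a ring is needed at all, which a methyl group or a short alkyl chain in the same place could test.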